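A Chloro for Isopropoxy Among Limit Values

The source may report more compounds than this note shows. Statements on the series, on what has been measured and on what is new or still open speak of the compounds shown alone.

Compound 1 (`COc1ccc(C2=C(c3cc(OC)c(OC)c(OC)c3)C(=O)C(OC(C)=O)C2)cc1OC(C)C`) was tested in an ADME assay on MIA PaCa-2 cells (Homo sapiens) for cytotoxicity, read by MTT assay, with a stated time of 72 h (on this read-out lower numbers stand for stronger inhibition and higher numbers for weaker inhibition), and gives > 100 ug/mL as a limit of the assay and not a number. Compound 2 (`COc1ccc(C2=C(c3cc(OC)c(OC)c(OC)c3)C(=O)CC2O[SiH2]C(C)(C)C)cc1`) gives > 100 ug/mL as a limit too. Compound 3 (`COc1ccc(C2=C(c3cc(OC)c(OC)c(OC)c3)C(=O)C(O[SiH2]C(C)(C)C)C2)cc1OC(C)C`) also gives > 100 ug/mL as a limit. Compound 1 therefore has no exact position on the scale of this assay.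

Compound 4 (`COc1ccc(C2=C(c3cc(OC)c(OC)c(OC)c3)C(=O)C(OC(C)=O)C2)cc1Cl`) carries chloro in place of isopropoxy on an aromatic carbon. Among the measured compounds shown here, the only measured step is a step that the two limits leave unreadable from compound 1 to compound 3 and it involves a different change, so it offers no size to carry over. For the measured compounds named here, for compound 4 no step beyond the scatter from compound 1 is expected because the limit of > 100 ug/mL in this assay, at which 3 of the 3 values shown sit, is the only guide available. Any measurable number would lie toward stronger inhibition. The expected change is a number no higher from compound 1 to compound 4 (the limit leaves the size open) in this estimate. Compound 4 is estimated at 100 ug/mL with an expected range from 30 ug/mL to 200 ug/mL. A limit of the assay rather than a number is also expected for compound 4.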

Compound 4, half-maximal inhibitory concentration: 24 ug/mL
Estimate against measurement, compound 4: 4.2-fold (0.62 log units) above, and the stated range ends above it.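

In this assay, chloro in place of isopropoxy on this aromatic carbon, ortho to a methoxy group, gives an at least 4.1-fold lower number from compound 1 to compound 4 (0.61 log units; beyond the scatter), and this size is only a minimum since compound 1 stands at a limit. The other step shown cannot be read, so this is the first sign that the series can be moved by a change at all, and here it is moved at this position rather than on the oxygen on a saturated carbon. Compound 4 alone has a number on the scale, while the other compounds rest at a limit: the limit of > 100 ug/mL in this assay, at which 3 of the 4 values shown sit.

Going by these compounds, whether the step belongs to chloro itself or to the loss of isopropoxy stays open, and a fluoro, a methyl or an amine at this position could tell these apart. Also open, on these data alone, is whether chloro would give a number with a hydroxyl or a longer chain on the saturated carbon.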